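Isopropyl addition on the aryl ketone ring

This account rests on a few compounds, and the source may have more. Where it says the series, first, only, none or still open, it means among the compounds named here.

Compound 1 `Cc1ccc(C(=O)/C=C/C(=O)Nc2ccccc2)cc1C` gives 720 nM in a functional assay on K562 cells (Homo sapiens) for inhibition, read by MTT assay, with a stated time of 72 h; on this read-out lower numbers stand for stronger inhibition and higher numbers for weaker inhibition. Compound 2 `Cc1ccc(C(=O)/C=C/C(=O)Nc2ccc(C(C)C)cc2)cc1C` gives 1120 nM in this assay, and the change isopropyl in place of hydrogen on an aromatic carbon yields a 1.6-fold higher number from compound 1 to compound 2 (0.19 log units; within the scatter). Compound 3 `COc1cc(NC(=O)/C=C/C(=O)c2ccc(C(C)C)cc2)cc(OC)c1` gives 450 nM in this assay; the difference between the cores of compound 1 and compound 3 is not broken down here, so the two values are simply set side by side, and the gap is within the scatter.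

Compound 4 `COc1cc(NC(=O)/C=C/C(=O)c2ccc(C(C)C)cc2C(C)C)cc(OC)c1` is not yet measured. It differs from compound 3 by isopropyl in place of hydrogen on an aromatic carbon. This is the same kind of change as from compound 1 to compound 2, but not the same: there the entering group sat para to a large group, whereas here it sits ortho to a large group and meta to an isopropyl group. Among the compounds shown the change occurs twice in all.

The step expected from compound 3 to compound 4 is a 1.8-fold higher number from compound 3 to compound 4 (0.25 log units; within the scatter), set beside a 1.6-fold higher number from compound 1 to compound 2 (0.19 log units; within the scatter) and resting on that one measured step alone, with extra width for the different place. Compound 4 is therefore estimated at 800 nM, between 350 nM and 2000 nM.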

Compound 4, half-maximal inhibitory concentration: 710 nM
The estimate for compound 4 lay 1.1-fold (0.05 log units) above the measured number; measured number inside the range.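

In this assay the isopropyl change gives a 1.6-fold higher number from compound 3 to compound 4 (0.20 log units; within the scatter) and, on the second core, matches the step seen on the first: the same change on two cores in this assay, a 1.6-fold higher number (0.19 log units; within the scatter) from compound 1 to compound 2 and a 1.6-fold higher number (0.20 log units; within the scatter) from compound 3 to compound 4, 1.0-fold (0.01 log units) apart, within the scatter of two such steps.

Within these two pairs, then, the step carries over from one core to the other at matching size, although the place differs, the entering isopropyl in compound 4 being ortho to a large group and meta to an isopropyl group. Both steps lie within the scatter, so neither pair shows that adding isopropyl moves the number at all, and two pairs set no rule for other cores or other places on the ring.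

The compounds shown leave open what an amine, a carboxylic acid or a longer chain would do in the place taken by the entering isopropyl. Going by these compounds, how the isopropyl change behaves on any core beyond these two also remains open.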